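This account rests on a few compounds, and the source may have more. Where it says the series, first, only, none or still open, it means among the compounds named here.

For the measured compounds named here, compound 1 `N#Cc1ccc(NC(=O)c2ccc(Br)cc2O)c(Cl)c1` shows the lowest of the two numbers measured so far in a functional assay on KG-1 cells (Homo sapiens) for cytotoxicity, read by luminescence and CellTiter-Glo, with a stated time of 3 days (on this read-out lower numbers stand for stronger inhibition and higher numbers for weaker inhibition), giving 790 nM. Going by the values given here, compound 2 `N#Cc1ccc(NC(=O)c2cc(C(F)(F)F)ccc2O)cc1` gives 4810 nM in this assay, and no single-change step connects these two. Compound 3 `N#Cc1ccc(NC(=O)c2ccc(Br)cc2O)cc1` has not yet been measured. The change from compound 1 to compound 3 is hydrogen in place of chloro on an aromatic carbon. Among the compounds with values here, with no measured step of this kind to lean on, the move in this assay is expected to be a modest weakening, somewhat beyond the scatter, estimated as a 2.5-fold higher number from compound 1 to compound 3 (0.40 log units; beyond the scatter). Compound 3 is therefore expected to give about 2000 nM, within a range from 800 nM to 5000 nM.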

Compound 3, half-maximal inhibitory concentration: 1450 nM
The estimate for compound 3 lay 1.4-fold (0.14 log units) above the measured number; measured number inside the range.
By their numbers in this assay, from the lowest: compounds 1 and 3 (each within the scatter of the next); then compound 2.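

Hydrogen in place of chloro on this aromatic carbon, meta to a cyano group, gives a 1.8-fold higher number from compound 1 to compound 3 (0.26 log units; within the scatter) in this assay, a step within the usual scatter. Compound 1 and compound 3 therefore cannot be told apart here, and the chloro group is not needed for activity at this level on the shared core. No measurement of any property of these compounds bears on this step. Still open, from the compounds shown here alone, is whether a fluoro, methoxy or amine group on this carbon would carry the number beyond the scatter in either direction.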